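The compounds below may be only part of what the source reports. "The series", "measured", "known", "first", "only" and "open" are said of these compounds alone.

Measured in an assay on HEK293 cells for inhibition of Fatty-acid amide hydrolase 1 (Homo sapiens), read by fluorescence; a lower number here means a stronger inhibitor, a higher number a weaker inhibitor:
- compound 1, `COCc1ccc(-c2ccc3oc(N4Cc5ccccc5C4)nc3c2)cc1`: 10 nM
- compound 2, `COCc1ccc(-c2ccc3oc(N4Cc5ccccc5C4)nc3c2)cc1OC`: 13 nM

Compound 1 holds the lowest of the two numbers in this assay; compound 2 sits nearest, and the step of a 1.3-fold higher number from compound 1 to compound 2 (0.11 log units; within the scatter) is within the scatter. Compound 3, `c1ccc2c(c1)CN(c1nc3cc(-c4ccc5nccn5c4)ccc3o1)C2`, differs from compound 1 by a group of 9 heavy atoms (7 carbon, 2 nitrogen; one five-membered aromatic ring with 2 hetero atoms, one six-membered aromatic ring with 1 hetero atom) in place of a group of 9 heavy atoms (8 carbon, 1 oxygen; one six-membered aromatic ring of carbon only), on an aromatic carbon. Going by the values given here, no measured step bears on this change: the one step recorded adds a methoxy and keeps the ring that compound 3 loses. The expectation for compound 3 therefore rests on compound 1 alone and carries wide uncertainty. Compound 3 is estimated at 25 nM, range 5 nM to 150 nM, an expected step of a 2.5-fold higher number from compound 1 to compound 3 (0.40 log units; beyond the scatter).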

Compound 3, half-maximal inhibitory concentration: 14 nM
The estimate for compound 3 lay 1.8-fold (0.25 log units) above the measured number; measured number inside the range.
By their numbers in this assay, from the lowest: compounds 1, 2 and 3 (each within the scatter of the next).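

In this assay, exchanging 4-(methoxymethyl)phenyl for the group with one five-membered and one six-membered aromatic ring gives a 1.4-fold higher number from compound 1 to compound 3 (0.15 log units; within the scatter). This aromatic carbon therefore accepts the loss of the carbon-only aromatic ring without a step beyond the scatter, which compound 2 could not show, as it keeps that ring. No supporting measurement explains this result.

Open, as far as these compounds go, is whether a single pyridine ring at this place would give a similar number. Also open, from the compounds shown here alone, is how an amine or a carboxylic acid would behave there.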